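Hydroxyphenyl-substituted pyridines against topoisomerase 1

A few compounds are considered here, and "the series" means these few. Any claim that something is new, unique, unknown or untested is made for them only; others in the source may bear on it.

Two compounds carry the shared core. Compound 1 `Oc1ccc(-c2cc(-c3ccsc3)cc(-c3ccc(O)cc3)n2)cc1` in an assay on isolated protein for inhibition of DNA topoisomerase 1 (Homo sapiens), with a stated time of 30 min, tested at 20 uM (a higher number here means a stronger effect of the compound at the concentration tested, a lower number a weaker effect), gives 7.5%. Compound 2 `Oc1ccc(-c2cc(-c3cccnc3)cc(-c3cccc(O)c3)n2)cc1` in this assay gives 2.8%, the lower of the two numbers, though compound 1 sits within the scatter of it. Compound 3 `Oc1ccc(-c2cc(-c3cccnc3)cc(-c3ccc(O)cc3)n2)cc1` has not yet been measured. It differs from compound 2 by 4-hydroxyphenyl in place of 3-hydroxyphenyl on an aromatic carbon. With both measured numbers low and within the scatter of each other, no step beyond the scatter is expected a number 2.2 percentage points higher from compound 2 to compound 3 (within the scatter). Compound 3 is estimated at 5%, with a range from 0% to 14%.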

Compound 3, a percentage reported as inhibition, at one concentration (the size of the read-out at that concentration, not a potency): 5%
Estimate against measurement, compound 3: no gap at the digits printed, within the range that was stated.
By their numbers in this assay, from the lowest: compounds 2, 3 and 1 (each within the scatter of the next).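

At the aromatic carbon next to the ring nitrogen, 4-hydroxyphenyl in place of 3-hydroxyphenyl gives a number 2.2 percentage points higher from compound 2 to compound 3 (within the scatter) in this assay and so leaves this swap unresolved. Pyridin-3-yl in place of thiophen-3-yl gives a number 2.5 percentage points lower from compound 1 to compound 3 (within the scatter) and is equally unresolved, so all three read-outs stay low and neither change separates from the scatter. No evidence on the reason for these numbers is at hand.

Open, on these data alone, is whether an amine or a carboxylic acid in place of the hydroxyl, or a longer chain in place of the pyridin-3-yl group, would give a step beyond the scatter.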